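Difluoromethoxy for methoxy on the benzyl of compound 2

This account rests on a few compounds, and the source may have more. Where it says the series, first, only, none or still open, it means among the compounds named here.

Compound 1 `Cc1nc(-c2nc(C(F)(F)F)no2)c(N)c2c1C(=O)N(Cc1ccccc1)C2=O` returns a limit rather than a number in a physicochemical assay for solubility, using the shake flask method, in simulated intestinal fluid, measured as kinetic solubility, with a stated time of 2 h, at 25 degrees C, at pH 6.5 (a lower number here means a less soluble compound, a higher number a more soluble compound), at < 5000 nM. Compound 2 `COc1ccc(CN2C(=O)c3c(C)nc(-c4nc(C)no4)c(N)c3C2=O)cc1` likewise gives only the limit < 5000 nM in this assay, and so stands with the limit of < 5000 nM in this assay, at which 2 of the 3 values shown sit. Compound 3 `Cc1noc(-c2nc(C)c3c(c2N)C(=O)N(C(C)c2ccccc2)C3=O)n1` gives 10900 nM in this assay, which reads as an at least 2.1-fold higher number from compound 2 to compound 3 (0.33 log units; beyond the scatter). Compound 4 `Cc1noc(-c2nc(C)c3c(c2N)C(=O)N(Cc2ccc(OC(F)F)cc2)C3=O)n1` differs from compound 2 by difluoromethyl in place of methyl on an oxygen on an aromatic ring. For the measured compounds named here, the only measured step changes the group on the ring nitrogen, not the group on this oxygen, so no measured step bears directly on the change. In this assay compound 4 is therefore expected to stay near the limit, with a step that the limit leaves unreadable from compound 2 to compound 4 not expected to exceed the scatter. The estimate for compound 4 is 4000 nM, between 1500 nM and 9000 nM.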

Compound 4, solubility: < 5000 nM
Compound 4 ended at the assay's limit; the forecaster's own chance of this, stated with the estimate: 65%; the middle value is on the limit's open side.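

Compound 2 and compound 4 both return only a limit in this assay, so no step between them can be read: the limit of < 5000 nM in this assay, at which 3 of the 4 values shown sit.

From the compounds shown here alone, whether methoxy to difluoromethoxy shifts the read-out at all in this assay stays open.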